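Branched ether side chains on the shared core: compound 4

This account rests on a few compounds, and the source may have more. Where it says the series, first, only, none or still open, it means among the compounds named here.

Compound 2 `CCC(C)COc1cccc2ccc(N)nc12` gives the lowest of the two numbers in an assay on cells with melanin-concentrating hormone receptor 1 (Homo sapiens) as the target, read by radioligand binding (on this read-out higher numbers stand for weaker inhibition and lower numbers for stronger inhibition), at 36 nM. Compound 1 `CC1CCC(Oc2cccc3ccc(N)nc23)C1` gives 823 nM in this assay. For compound 3 `CCOCCOc1cccc2ccc(N)nc12` the result is a limit rather than a number, > 2000 nM. Compound 3 sits at the limit of > 2000 nM in this assay, at which 1 of the 3 values shown sits. Compound 4 `Nc1ccc2cccc(OCCC3CC3)c2n1` differs from compound 2 in one place: cyclopropylmethyl in place of sec-butyl on a saturated chain carbon bound to an oxygen on an aromatic ring. Among the measured compounds shown here, two measured steps bear on this change. a 23-fold lower number from compound 1 to compound 2 (1.36 log units; beyond the scatter); an at least 55-fold higher number from compound 2 to compound 3 (1.74 log units; beyond the scatter). Both concern how the side chain on the oxygen is built. Compound 4 keeps a hydrocarbon chain of the same size as compound 2 and brings in no oxygen, so the large loss seen on going to compound 3 is not expected, while the small ring recalls, in a smaller form, the cyclic chain of compound 1. A modest rise in the number, near the edge of the scatter, is the expected outcome, and the expected step is a 2.2-fold higher number from compound 2 to compound 4 (0.35 log units; beyond the scatter). Compound 4 is therefore estimated at 80 nM in this assay, with a range from 25 nM to 250 nM.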

Compound 4, half-maximal inhibitory concentration: 492 nM
Compound 4: the middle estimate sits 6.2-fold (0.79 log units) below what was measured; measured number outside the range, above it.
By their numbers in this assay, from the lowest: compound 2; then compounds 4 and 1 (each within the scatter of the next). At a limit, above all of these: compound 3.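

In this assay, cyclopropylmethyl in place of sec-butyl gives a 14-fold higher number from compound 2 to compound 4 (1.14 log units; beyond the scatter) and so shows that this position can lose much without any oxygen entering the chain. Compound 4 still compares well with the ethoxy-bearing chain, with an at least 4.0-fold lower number from compound 3 to compound 4 (0.60 log units; beyond the scatter) resting on the limit held by compound 3. With a 1.7-fold lower number from compound 1 to compound 4 (0.22 log units; within the scatter) the two ring-bearing chains stand together, yet a ring does not sort the series alone, since compound 3 has no ring and also goes against any link between an open chain and a low number.

Open, on these data alone, is whether the low number of compound 2 depends on its branch or on an open hydrocarbon chain, and what a longer chain such as n-hexyl or a terminal amine would give. Nothing measured here accounts for the step to compound 4.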